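Adding a methyl to compound 2

The source may report more compounds than this note shows. Statements on the series, on what has been measured and on what is new or still open speak of the compounds shown alone.

Measured so far in a physicochemical assay for solubility, in phosphate buffer, with a stated time of 2 h; on this read-out higher numbers stand for higher solubility and lower numbers for lower solubility:
Compound 1 `Cc1nc(-c2ccc(-c3ccccc3)cc2)sc1-c1nnc(N2CC(O)C2)o1` gives 150000 nM
Compound 2 `Cc1nc(-c2ccc(-c3ccccc3)cc2)sc1-c1nnc(NC(=N)N)o1` gives 128000 nM

On these numbers, compound 2 stands within the scatter of compound 1, so neither can be ranked over the other. The next compound, compound 3 `CNC(=N)Nc1nnc(-c2sc(-c3ccc(-c4ccccc4)cc3)nc2C)o1`, carries one change from compound 2 (methyl in place of hydrogen on an amine nitrogen), namely methyl in place of hydrogen on an amine nitrogen. Within the data shown here, only one measured step bears on this, and only loosely (a 1.2-fold lower number from compound 1 to compound 2 (0.07 log units; within the scatter)). That step exchanged a whole group on an aromatic carbon and stayed within the scatter. Among the measured compounds shown here, no measured step shows methyl in place of hydrogen on an amine nitrogen, so the data offer no direct precedent. Resting on compound 2 at 128000 nM and on that single small step, no change beyond the scatter is expected in this assay for this smaller edit. The expected step is a 1.2-fold lower number from compound 2 to compound 3 (0.07 log units; within the scatter) on this estimate. Compound 3 is estimated at 110000 nM with an expected range from 45000 nM to 200000 nM in this measurement.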

Compound 3, solubility: 89000 nM
Compound 3: the middle estimate sits 1.2-fold (0.09 log units) above what was measured; the measured number falls inside the stated range.
By their numbers in this assay, from the lowest: compounds 3, 2 and 1 (each within the scatter of the next).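

In this assay, among these compounds, methyl in place of hydrogen on an amine nitrogen, whose other neighbour is a carbon with a double bond to nitrogen, gives the first direct reading of this edit (a 1.4-fold lower number from compound 2 to compound 3 (0.16 log units; within the scatter)), and that step stays within the scatter. Among the compounds shown here, the group that compound 3 carries on the aromatic carbon can also be read against the one in compound 1 (a 1.7-fold lower number from compound 1 to compound 3 (0.23 log units; within the scatter)), and this step also stays within the scatter, so the three compounds cannot be ranked and no change at this place has yet moved the read-out beyond the scatter. No measured evidence bears on what lies behind these numbers.

The compounds shown leave open whether a longer chain on that same amine nitrogen, such as ethyl or propyl, or a second methyl there, would give a step beyond the scatter. They also leave open what a carboxylic acid or a simple amine would do in place of the whole group on the aromatic carbon, since every group seen there so far gives numbers within the scatter of each other.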